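Replacing a formyl group in a series at its limit

A few compounds are considered here, and "the series" means these few. Any claim that something is new, unique, unknown or untested is made for them only; others in the source may bear on it.

In a functional assay on NALM-6 cells (Homo sapiens) for cytotoxicity, with a stated time of 72 h (on this read-out lower numbers stand for an effect already at smaller amounts and higher numbers for an effect only at larger amounts of compound), three compounds have been measured so far. Compound 1 `C=C[C@@](C)(/C=C/c1ccc(O)cc1)CC/C=C(\C)C(=O)OCC` gives only a limit of the assay, > 43400 nM. Compound 2 `C=C[C@@](C)(/C=C/c1ccc(O)c(/C=C/C(=O)c2ccccc2)c1)CCC=C(C)C` gives a true number, 4470 nM. Compound 3 `COc1ccc(/C=C/[C@@](C)(/C=C/c2ccc(O)c(C=O)c2)CCC=C(C)C)cc1` likewise gives only a limit, > 43400 nM, so its real position is not known.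

Compound 4 `CCOC(=O)/C=C/c1cc(/C=C/[C@](C)(/C=C/c2ccc(OC)cc2)CCC=C(C)C)ccc1O` carries 2-(ethoxycarbonyl)ethenyl in place of the formyl of compound 3 on an aromatic carbon, ortho to a hydroxy group: 2-(ethoxycarbonyl)ethenyl in place of formyl on an aromatic carbon. Within the data shown here, no measured pair in this small set shows such a change, so the size of the step cannot be read directly. Compound 2, at 4470 nM, shows that a true number can be reached among these compounds. A moderate step in this assay toward lower numbers is therefore expected, though compound 4 may well remain at the limit. The expected change is an at least 2.8-fold lower number from compound 3 to compound 4 (0.46 log units; beyond the scatter). Compound 4 is estimated at 15000 nM, with an expected range from 4000 nM to 43400 nM.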

Compound 4, half-maximal effective concentration: > 43400 nM
Compound 4: only a limit was reported (the forecaster's own chance of this, stated with the estimate: 45%); middle value at least 2.8-fold (0.46 log units) away from the limit.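

Compound 3 and compound 4 both sit at a limit of the assay, so no step between them can be read: the limit of > 43400 nM in this assay, at which 3 of the 4 values shown sit.

The compounds shown leave open whether 2-(ethoxycarbonyl)ethenyl in place of formyl changes the read-out at all, and if so, in which direction and by how much.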